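Octyl Back to 3-Chlorophenyl on the Hydroxy Anilide

The source may report more compounds than this note shows. Statements on the series, on what has been measured and on what is new or still open speak of the compounds shown alone.

Compound 1, `O=C(Nc1ccccc1C(F)(F)F)C1CCc2ccccc2N1C(=O)c1cccc(Cl)c1`: 288 nM
Compound 2, `CCCCCCCCC(=O)N1c2ccccc2CCC1C(=O)Nc1ccccc1C(F)(F)F`: 3350 nM
Compound 3, `CCCCCCCCC(=O)N1c2ccccc2CCC1C(=O)Nc1ccccc1O`: 54300 nM

All three share one core and were tested in a functional assay on MDA-MB-231 cells (Homo sapiens) for cytotoxicity, read by sulforhodamine B assay, with a stated time of 72 h; a lower number here means a stronger inhibitor of growth, a higher number a weaker inhibitor of growth. Compound 3 stands highest of the three numbers; its nearest neighbour is compound 2, separated by a 16-fold higher number from compound 2 to compound 3 (1.21 log units; beyond the scatter), and compound 1 lies further away still. Compound 4, `O=C(Nc1ccccc1O)C1CCc2ccccc2N1C(=O)c1cccc(Cl)c1`, differs from compound 3 by 3-chlorophenyl in place of octyl on a carbonyl carbon. Going by the values given here, one measured step bears directly on this change, run in the opposite direction: a 12-fold higher number from compound 1 to compound 2 (1.07 log units; beyond the scatter), a large shift. Reversing that change on compound 3 is therefore expected to give a large drop in this assay, beyond the scatter. Compound 4 is estimated at 4500 nM, within 1500 nM to 15000 nM, which would mean an expected step of a 12-fold lower number from compound 3 to compound 4 (1.08 log units; beyond the scatter).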

Compound 4, concentration for 50% growth inhibition: 10600 nM
Estimate against measurement, compound 4: 2.4-fold (0.37 log units) below; the measured number falls inside the stated range.
By their numbers in this assay, from the lowest: compound 1; then compound 2; then compound 4; then compound 3.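

In this assay, 3-chlorophenyl in place of octyl on the carbonyl carbon again lowers the number, now with the hydroxy group on the anilide, giving a 5.1-fold lower number from compound 3 to compound 4 (0.71 log units; beyond the scatter); the change therefore runs the same way on two cores, with sizes that agree: the same change on two cores in this assay, a 12-fold higher number (1.07 log units; beyond the scatter) from compound 1 to compound 2 and a 5.1-fold higher number (0.71 log units; beyond the scatter) from compound 4 to compound 3, 2.3-fold (0.36 log units) apart, within the scatter of two such steps. Hydroxy in place of trifluoromethyl also raises the number with 3-chlorophenyl present, giving a 37-fold higher number from compound 1 to compound 4 (1.57 log units; beyond the scatter), which agrees with the same change on the octyl pair: the same change on two cores in this assay, a 16-fold higher number (1.21 log units; beyond the scatter) from compound 2 to compound 3 and a 37-fold higher number (1.57 log units; beyond the scatter) from compound 1 to compound 4, 2.3-fold (0.36 log units) apart, within the scatter of two such steps. Across these four compounds, each change keeps its direction whichever group occupies the other place.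

Going by these compounds, it remains open how a shorter chain or an amine on that carbonyl carbon would compare with octyl and 3-chlorophenyl. On these data alone, it is equally open where a methoxy group on the aromatic carbon would fall relative to hydroxy and trifluoromethyl.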